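The source may report more compounds than this note shows. Statements on the series, on what has been measured and on what is new or still open speak of the compounds shown alone.

Compound 1 `O=C(Nc1ccc(-n2ncc3c(F)cccc32)cc1)Nc1ccc(Cl)c(C(F)(F)F)c1` stands highest of the two numbers in a functional assay on Bel-7402 cells (Homo sapiens) for cytotoxicity, read by MTT assay, with a stated time of 72 h (on this read-out higher numbers stand for weaker inhibition and lower numbers for stronger inhibition), where compound 1 gives 16000 nM. Going by the values given here, compound 2 `COc1cccc2c1cnn2-c1ccc(NC(=O)Nc2ccc(Cl)c(C(F)(F)F)c2)cc1` gives 2900 nM in this assay; the single measured step, a 5.5-fold lower number from compound 1 to compound 2 (0.74 log units; beyond the scatter), rests on methoxy in place of fluoro on an aromatic carbon. Compound 3 `O=C(Nc1ccc(-n2ncc3cccnc32)cc1)Nc1ccc(Cl)c(C(F)(F)F)c1` differs from compound 1 by a group of 9 heavy atoms (6 carbon, 3 nitrogen; one five-membered aromatic ring with 2 hetero atoms, one six-membered aromatic ring with 1 hetero atom) in place of a group of 10 heavy atoms (7 carbon, 2 nitrogen, 1 fluorine; one five-membered aromatic ring with 2 hetero atoms, one six-membered aromatic ring of carbon only), on an aromatic carbon: a group of 9 heavy atoms (6 carbon, 3 nitrogen; one five-membered aromatic ring with 2 hetero atoms, one six-membered aromatic ring with 1 hetero atom) in place of a group of 10 heavy atoms (7 carbon, 2 nitrogen, 1 fluorine; one five-membered aromatic ring with 2 hetero atoms, one six-membered aromatic ring of carbon only), on an aromatic carbon, para to a large group. Among the compounds with values here, no measured step exchanges the whole bicyclic group; the only bearing comes from the modest change seen when that group was altered in compound 2. Compound 3 is therefore expected to shift only modestly, a 1.8-fold lower number from compound 1 to compound 3 (0.25 log units; within the scatter), with direction uncertain. Compound 3 is estimated at 9000 nM, range 3000 nM to 30000 nM.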

Compound 3, half-maximal inhibitory concentration: 20900 nM
Compound 3: middle estimate off by 2.3-fold (0.37 log units), on the low side; measured number inside the range.
By their numbers in this assay, from the lowest: compound 2; then compounds 1 and 3 (each within the scatter of the next).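

In this assay, exchanging the 4-fluoro-1H-indazol-1-yl group, on an aromatic carbon para to a large group, for the group with a hetero atom in its six-membered ring gives a 1.3-fold higher number from compound 1 to compound 3 (0.12 log units; within the scatter), so the two compounds cannot be told apart in this assay. Going by these compounds alone, at this position, then, the whole bicyclic group can be exchanged without a readable shift, while the only step beyond the scatter remains a 5.5-fold lower number from compound 1 to compound 2 (0.74 log units; beyond the scatter), from a substituent exchange on the bicyclic group. Nothing available explains why the exchange leaves the number within the scatter.

As far as these compounds go, it remains open whether the methoxy of compound 2 would have the same effect on the group carried by compound 3. Also open, from the compounds shown here alone, is what an amine or a longer chain such as ethoxy would do in place of the fluoro of compound 1.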